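This account rests on a few compounds, and the source may have more. Where it says the series, first, only, none or still open, it means among the compounds named here.

Measured so far:
compound 1 `COc1ccc(CNc2ncnc3c2ncn3[C@@H]2O[C@H](CO)[C@@H](O)[C@H]2O)c(OC)c1` – > 166000 nM
compound 2 `OC[C@H]1O[C@@H](n2cnc3c(NCc4ccc(F)c(Cl)c4)ncnc32)[C@H](O)[C@@H]1O` – 3400 nM

In a functional assay on CCRF-CEM cells (Homo sapiens) for antiproliferative activity, with a stated time of 72 h (a lower number here means a stronger inhibitor, a higher number a weaker inhibitor), compound 1 gives only a limit, > 166000 nM. Compound 2 gives 3400 nM in this assay, the only plain number shown, so it stands alone among the measured compounds. For the measured compounds named here, the single measured comparison is an at least 48-fold lower number from compound 1 to compound 2 (1.68 log units; beyond the scatter), and it rests on a limit (the limit of > 166000 nM in this assay, at which 1 of the 2 values shown sits).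

Compound 3 `COc1cccc(CNc2ncnc3c2ncn3[C@@H]2O[C@H](CO)[C@@H](O)[C@H]2O)c1O` is not yet measured. It differs from compound 2 in one place: 2-hydroxy-3-methoxyphenyl in place of 3-chloro-4-fluorophenyl on a saturated chain carbon bound to a nitrogen on an aromatic ring. The group entering is, like that of compound 1, oxygenated rather than halogenated. Going by the values given here, only the step of an at least 48-fold lower number from compound 1 to compound 2 (1.68 log units; beyond the scatter) bears on this change, and it was large; a return to an oxygenated ring is therefore expected to run the other way, giving a large rise in this assay, that is a 24-fold higher number from compound 2 to compound 3 (1.37 log units; beyond the scatter). Compound 3 is estimated at 80000 nM, between 15000 nM and 400000 nM, with a fair chance that only a limit is reported.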

Compound 3, half-maximal inhibitory concentration: 300 nM
Compound 3: the middle estimate sits 270-fold (2.43 log units) above what was measured; the whole stated range lies above it.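

Replacing 3-chloro-4-fluorophenyl with 2-hydroxy-3-methoxyphenyl on a saturated chain carbon bound to a nitrogen on an aromatic ring gives an 11-fold lower number from compound 2 to compound 3 (1.05 log units; beyond the scatter) in this assay, so at this position an oxygenated ring can outdo a halogenated one. Between the two oxygenated rings, 2-hydroxy-3-methoxyphenyl in place of 2,4-dimethoxyphenyl gives an at least 550-fold lower number from compound 1 to compound 3 (2.74 log units; beyond the scatter), so the presence of oxygen on the ring does not decide the outcome; which groups the ring carries does. This last step rests on a limit, so its full size stays unknown: the limit of > 166000 nM in this assay, at which 1 of the 3 values shown sits.

The hydroxy and methoxy groups enter together, and the compounds shown do not tell whether one of them alone accounts for the gain. A ring carrying only a hydroxy group, or an amine in its place, remains an open case.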